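Bromo to chloro exchange in a growth-inhibition series

This account rests on a few compounds, and the source may have more. Where it says the series, first, only, none or still open, it means among the compounds named here.

Three compounds have been measured in a functional assay on T47D cells (Homo sapiens) for inhibition, read by sulforhodamine B assay, with a stated time of 48 h; on this read-out lower numbers stand for stronger inhibition of growth and higher numbers for weaker inhibition of growth:

Compound 1, `COC(=O)[C@@]1(C)CCC=C2[C@@H]1CC[C@@H](C)[C@]2(C)Cc1c[nH]c2ccc(Br)cc12`, gives 16000 nM.
Compound 2, `COC(=O)[C@@]1(C)CCC=C2[C@@H]1CC[C@@H](C)[C@]2(C)Cc1c[nH]c2ccc(Cl)cc12`, gives 17000 nM.
Compound 3, `COC(=O)[C@@]1(C)CCC=C2[C@@H]1CC[C@@H](C)[C@]2(C)Cc1c(C)[nH]c2c(Br)cccc12`, gives 31000 nM.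

Compound 2 differs from compound 1 by chloro in place of bromo on an aromatic carbon, and this step produced a 1.1-fold higher number from compound 1 to compound 2 (0.03 log units; within the scatter). Compound 3 carries a different core; the difference between the core of compound 1 and the core of compound 3 is not broken down here. Its value lies within the scatter of both compound 1 and compound 2, so no order among the three can be drawn.

Compound 4, `COC(=O)[C@@]1(C)CCC=C2[C@@H]1CC[C@@H](C)[C@]2(C)Cc1c(C)[nH]c2c(Cl)cccc12`, has not yet been measured. It differs from compound 3 by chloro in place of bromo on an aromatic carbon. This is the same kind of change as that from compound 1 to compound 2, but not at the same place: in compound 1 the halogen sits meta to a fused ring and para to a fused ring, whereas in compound 3 it sits ortho to a fused ring and meta to a fused ring. Going by the values given here, the expectation rests on the single measured instance of this kind of change, a 1.1-fold higher number from compound 1 to compound 2 (0.03 log units; within the scatter), which stayed within the scatter. The step from compound 3 to compound 4 in this assay is therefore expected to be a 1.1-fold higher number from compound 3 to compound 4 (0.04 log units; within the scatter). Compound 4 is estimated at 34000 nM, with a range from 15000 nM to 75000 nM.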

Compound 4, concentration for 50% growth inhibition: 27000 nM
For compound 4 the middle estimate is 1.3-fold (0.10 log units) above the measured one; measured number inside the range.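

In this assay, chloro in place of bromo on the core of compound 3 gave a 1.1-fold lower number from compound 3 to compound 4 (0.06 log units; within the scatter), and the same exchange on the core of compound 1 gave a 1.1-fold higher number from compound 1 to compound 2 (0.03 log units; within the scatter). Set side by side, the two steps cannot be told apart, and on these two cores the exchange carried over with no step beyond the scatter: the same change on two cores in this assay, a 1.1-fold higher number (0.03 log units; within the scatter) from compound 1 to compound 2 and a 1.1-fold lower number (0.06 log units; within the scatter) from compound 3 to compound 4, 1.2-fold (0.09 log units) apart, within the scatter of two such steps. This shows that, in these two matched pairs, bromo and chloro could stand in for each other on the aromatic ring without a measurable difference in this read-out, but it rests on two pairs only, says nothing about a third core or about any other cell line or assay, and does not tell whether a step beyond the scatter would also carry from one core to the other.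

The compounds shown carry only bromo or chloro on the aromatic ring and share the methyl ester throughout. Going by these compounds, what a fluoro, a methoxy or an amine on the same aromatic carbon would give remains open, as does the effect of a carboxylic acid in place of the methyl ester on either core.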